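This account rests on a few compounds, and the source may have more. Where it says the series, first, only, none or still open, it means among the compounds named here.

Values so far in a functional assay on MV4-11 cells (Homo sapiens) for antiproliferative activity, read by luminescence and CellTiter-Glo, with a stated time of 72 h (a lower number here means a stronger inhibitor, a higher number a weaker inhibitor), are as follows

compound 1 `COc1cc(F)ccc1Nc1nn(C2CCCCO2)c2ccc(-c3c(C)noc3C)cc12` gives 17500 nM
compound 2 `CNc1cc(-c2ccc3cnn(Cc4cc(OC)cc(OC)c4)c3c2)cn(C)c1=O` gives 190 nM
compound 3 `CCNc1cc(-c2ccc3cnn(Cc4cc(OC)cc(OC)c4)c3c2)cn(C)c1=O` gives 2590 nM

Compound 2 holds the lowest number of the three, and the gaps to compound 3 and compound 1 both lie beyond the scatter. Compound 1 lies furthest from it.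

Not yet measured is compound 4 `CCOC(=O)Cn1ncc2ccc(-c3cc(NC)c(=O)n(C)c3)cc21`. The change is ethoxycarbonyl in place of 3,5-dimethoxyphenyl on a saturated chain carbon bound to an aromatic nitrogen and amounts to ethoxycarbonyl in place of 3,5-dimethoxyphenyl on a saturated chain carbon bound to an aromatic nitrogen. The one-ring loss is thus the main feature of the change.

Among the measured compounds shown here, no measured step touches this place. For the measured compounds named here, the only step available is a 14-fold higher number from compound 2 to compound 3 (1.13 log units; beyond the scatter) and it is large, but it concerns methyl in place of hydrogen on a saturated chain carbon bound to a nitrogen on an aromatic ring. It bears only indirectly, showing that one small edit can move this series well beyond the scatter.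

Going by the values given here, with compound 2 at 190 nM as the lowest number so far, a higher number is the likelier direction in this assay, and a step of similar size is expected, though with wide uncertainty.

For compound 4 the estimated value is 2000 nM in the middle.
The expected range for compound 4 runs from 500 nM to 10000 nM as an estimate.
The expected change is an 11-fold higher number from compound 2 to compound 4 (1.02 log units; beyond the scatter) on this estimate.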

Compound 4, half-maximal inhibitory concentration: 8770 nM
The estimate for compound 4 lay 4.4-fold (0.64 log units) below the measured number; low and high end bracket the measured number.
By their numbers in this assay, from the lowest: compound 2; then compound 3; then compounds 4 and 1 (each within the scatter of the next).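

In this assay, the group on the saturated chain carbon bound to an aromatic nitrogen now has a measured step of its own: ethoxycarbonyl in place of 3,5-dimethoxyphenyl gives a 46-fold higher number from compound 2 to compound 4 (1.66 log units; beyond the scatter), so the activity of compound 2 does not survive this exchange. The counts of hydrogen-bond donors and acceptors are the same for the leaving and the entering group, so those counts do not separate compound 2 from compound 4, whereas the aromatic ring and the number of heavy atoms do differ. Nothing shown here gives a measured reason for the step, and it stands as an observation only.

A single pair cannot tell whether the step follows the loss of the aromatic ring, the removal of the two methoxy groups, or the arrival of the ester. From the compounds shown here alone, how an unsubstituted phenyl, a pyridine ring or a carboxylic acid on this same carbon would read in this assay stays open, and any of these would help to separate those three readings.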